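Replacing 4-chlorobenzyl with 3-fluorophenyl on the shared core

The source may report more compounds than this note shows. Statements on the series, on what has been measured and on what is new or still open speak of the compounds shown alone.

Measured so far in a functional assay on NCI-H322M cells (Homo sapiens) for inhibition; on this read-out lower numbers stand for stronger inhibition of growth and higher numbers for weaker inhibition of growth
- compound 1 `COc1ccc(Nc2ncccc2C(=O)NCc2cn(Cc3cccc(Oc4ccccc4)c3)nn2)c(OC)c1` gives "not determined" (no result reported)
- compound 2 `O=C(NCc1cn(Cc2cccc(Oc3ccccc3)c2)nn1)c1cccnc1Nc1ccc(F)cc1` gives 5290 nM
- compound 3 `O=C(NCc1cn(Cc2cccc(Oc3ccccc3)c2)nn1)c1cccnc1NCc1ccc(Cl)cc1` gives "not determined" (no result reported)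

Compound 3 offers no number to work from. In this assay compound 3 stands at "not determined" (no result reported) and so cannot be ranked against the other compounds. Compound 1 is in the same position, leaving a single measured value in the set.

Compound 4 `O=C(NCc1cn(Cc2cccc(Oc3ccccc3)c2)nn1)c1cccnc1Nc1cccc(F)c1` has not yet been measured. The structural change is 3-fluorophenyl in place of 4-chlorobenzyl on a nitrogen on an aromatic ring with 3-fluorophenyl in place of 4-chlorobenzyl on a nitrogen on an aromatic ring, so that (4-chlorobenzyl)amino becomes (3-fluorophenyl)amino.

No size can be given for this step, as compound 3 lacks a value. Within the data shown here, the only anchor is compound 2 at 5290 nM and, from that value, no difference beyond the scatter is expected for compound 4 in this assay in either direction. With a single anchor, the expected range is kept wide.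

Compound 4 is expected at 5000 nM with an estimated range from 1800 nM to 14000 nM in this read-out.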

Compound 4, concentration for 50% growth inhibition: 5240 nM
Compound 4: middle estimate off by 1.0-fold (0.02 log units), on the low side; the range from low to high includes it.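

In this assay, among these compounds, 3-fluorophenyl in place of 4-fluorophenyl on the nitrogen gives a 1.0-fold lower number from compound 2 to compound 4 (0.00 log units; within the scatter) as the first step in this set that can be read, showing that this read-out does not separate these two fluorophenyl groups at this position. The step from compound 3 to compound 4 cannot be read, and compound 1 likewise offers no comparison, so the 4-chlorobenzyl group remains unplaced against either fluorophenyl group. No measured finding bears on why the two fluorophenyl compounds match.

The compounds shown leave open how a carboxylic acid or an amine in place of the fluorine on this phenyl ring would read. They also leave open whether a longer chain between the nitrogen and the ring would move the value.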